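Cytotoxicity on Vero cells across a carbamate-to-amide series

The source may report more compounds than this note shows. Statements on the series, on what has been measured and on what is new or still open speak of the compounds shown alone.

Measured compounds:
compound 1 `CCN(CC)c1cc2[nH]c(C3CCCCC3)nc2cc1NC(=O)OCC(F)(F)F` — > 100 ug/mL
compound 2 `C=Cc1cccc(C(=O)Nc2cc3nc(C4CCCCC4)[nH]c3cc2N(CC)CC)c1` — > 100 ug/mL

The account concerns an ADME assay on Vero cells (Chlorocebus sabaeus) for cytotoxicity, read by resazurin assay, with a stated time of 3 days; a higher number here means a weaker inhibitor, a lower number a stronger inhibitor. Compound 1 `CCN(CC)c1cc2[nH]c(C3CCCCC3)nc2cc1NC(=O)OCC(F)(F)F` gives only a limit in this assay, > 100 ug/mL. Compound 2 `C=Cc1cccc(C(=O)Nc2cc3nc(C4CCCCC4)[nH]c3cc2N(CC)CC)c1` likewise reaches only a limit, > 100 ug/mL. The step that the two limits leave unreadable from compound 1 to compound 2 therefore cannot be read in size, since both ends sit at a limit, as the limit of > 100 ug/mL in this assay, at which 2 of the 2 values shown sit, records. Compound 2 thus stands at the upper limit of this assay, with no numerical value of its own.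

Compound 3 `CCOCCOC(=O)Nc1cc2nc(C3CCCCC3)[nH]c2cc1N(CC)CC` is not yet measured. It differs from compound 2 in one place: 2-ethoxyethoxy in place of 3-vinylphenyl on a carbonyl carbon. For the measured compounds named here, the only measured step that bears on this change is the one from compound 1 to compound 2, which is unreadable because a step that the two limits leave unreadable from compound 1 to compound 2 joins two limits. Going by the values given here, no step of readable size is available, so no change beyond the scatter is expected in this assay.

Compound 3 is expected to remain at or near the limit, with an estimated step of a number no higher from compound 2 to compound 3 (the limit leaves the size open). For compound 3 the estimate in this assay is 100 ug/mL, ranging from 40 ug/mL to 250 ug/mL.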

Compound 3, half-maximal inhibitory concentration: > 100 ug/mL
Compound 3 ended at the assay's limit; the forecaster's own chance of this, stated with the estimate: 75%; the middle value sits exactly at the limit.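

Compound 3 gives only a limit in this assay, > 100 ug/mL. For the compounds shown here, no step among compound 1, compound 2 and compound 3 can be read in size, since all three sit at the same limit: the limit of > 100 ug/mL in this assay, at which 3 of the 3 values shown sit. The compounds shown leave open where each half-maximal inhibitory concentration truly lies, and so whether the groups on the carbonyl carbon make any difference.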